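The source may report more compounds than this note shows. Statements on the series, on what has been measured and on what is new or still open speak of the compounds shown alone.

Measured so far:
Compound 1 `Cc1cc(NC(=O)Nc2cccc(F)c2)c2ccccc2n1` – > 25000 nM in an ADME assay on Raji cells (Homo sapiens) for cytotoxicity, with a stated time of 72 h (a lower number here means that less compound is needed, a higher number that more compound is needed for the effect), a limit of the assay.
Compound 2 `Cc1cc(NC(=O)Nc2ccc(C(N)=O)cc2)c2ccccc2n1` – > 25000 nM in this assay, again a limit.

For the measured compounds named here, compound 2 therefore stands at the limit, not at a number, and the limit of > 25000 nM in this assay, at which 2 of the 2 values shown sit, means the one other value stands at the same limit. Compound 3 `Cc1cc(NC(=O)Nc2ccc(Cl)cc2)c2ccccc2n1` differs from compound 2 in one place: chloro in place of carbamoyl on an aromatic carbon. Going by the values given here, no step between measured compounds exists here, so for this assay no change beyond the usual scatter is expected a step that the limit leaves unreadable from compound 2 to compound 3. Compound 3 is estimated at 30000 nM, with a likely range from 12000 nM to 80000 nM, most probably reported again as a limit.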

Compound 3, half-maximal effective concentration: > 25000 nM
Compound 3 gave a limit, no number; the forecaster's own chance of this, stated with the estimate: 70%; the middle value is on the limit's open side.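

Compound 3 also gives only a limit, so no step can be read from compound 1 or compound 2 to compound 3: the limit of > 25000 nM in this assay, at which 3 of the 3 values shown sit. The compounds shown leave open whether any of them differs from the others in this assay, since none has a numerical value.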